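The source may report more compounds than this note shows. Statements on the series, on what has been measured and on what is new or still open speak of the compounds shown alone.

Measured values in a functional assay on MCF7 cells (Homo sapiens) for inhibition, read by CCK-8 assay, with a stated time of 48 h (on this read-out lower numbers stand for stronger inhibition of growth and higher numbers for weaker inhibition of growth), stand as follows:
compound 1 `Cc1ccccc1Nc1nc(Nc2cccnc2)ncc1Cl` gives 56500 nM as a number
compound 2 `Cc1ccccc1Nc1nc(NC2CCCCC2)ncc1Cl` gives > 100000 nM as a limit
compound 3 `Cc1ccc(Nc2ncc(Cl)c(Nc3ccccc3C)n2)cc1` gives > 100000 nM as a limit

Compound 3 thus stands at a limit of the assay, with no number of its own. Across this small set, the limit of > 100000 nM in this assay, at which 2 of the 3 values shown sit, is the main fact, and only compound 1 has a real number.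

Compound 4 `Cc1ccccc1Nc1nc(NCc2ccccc2)ncc1Cl` differs from compound 3 as follows: benzyl in place of 4-methylphenyl on a nitrogen on an aromatic ring with benzyl in place of 4-methylphenyl on a nitrogen on an aromatic ring, the same atoms joined differently.

Within the data shown here, two measured steps concern this same place, namely an at least 1.7-fold higher number from compound 1 to compound 2 (0.24 log units; that floor lies within the scatter) and an at least 1.7-fold higher number from compound 1 to compound 3 (0.24 log units; that floor lies within the scatter) and both floors lie within the scatter. A third, a step that the two limits leave unreadable from compound 2 to compound 3 has no readable size. Changes on this nitrogen have therefore shown nothing beyond the scatter so far, and none is expected from this one. In this assay the estimated step is an at least 1.2-fold lower number from compound 3 to compound 4 (0.09 log units; that floor lies within the scatter) with no clear direction expected. Compound 4 is expected near 80000 nM with an estimated range from 30000 nM to 200000 nM on this read-out, and it may well report only a limit.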

Compound 4, concentration for 50% growth inhibition: > 100000 nM
Compound 4: a limit, no number (the forecaster's own chance of this, stated with the estimate: 50%); middle value at least 1.2-fold (0.09 log units) away from the limit.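

Benzyl carries the same atoms as 4-methylphenyl, joined differently, yet in this assay this rearrangement on the nitrogen still gives no number for compound 4, only a limit, so its steps to the two other compounds held at a limit cannot be read. Among these compounds, the one readable step is an at least 1.7-fold higher number from compound 1 to compound 4 (0.24 log units; that floor lies within the scatter), so benzyl cannot yet be told apart from pyridin-3-yl, just as cyclohexyl and 4-methylphenyl could not. With this result, four different groups on this nitrogen show no change beyond the scatter, and the set gathers ever more closely at one boundary: the limit of > 100000 nM in this assay, at which 3 of the 4 values shown sit.

From the compounds shown here alone, it remains open whether a phenyl ring bearing a carboxylic acid, or a longer chain ending in an amine, on this nitrogen would bring a value well clear of that limit. Also open, going by these compounds, is what a change elsewhere on the shared core would do, such as a bromine in place of the chlorine.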